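Cyclopropylidene nucleoside analogues: cytotoxicity on fibroblasts

This account rests on a few compounds, and the source may have more. Where it says the series, first, only, none or still open, it means among the compounds named here.

Measured compounds, in an ADME assay on HFF cells (Homo sapiens) for cytotoxicity, with a stated time of 8 days; a higher number here means that more compound is tolerated, a lower number that less compound is tolerated:
- compound 1 `Nc1nc(OCC(F)(F)F)c2ncn(/C=C3/CC3(CO)CO)c2n1`: > 300000 nM, a limit of the assay
- compound 2 `Nc1nc(NCc2ccccc2)c2ncn(/C=C3/CC3(CO)CO)c2n1`: > 300000 nM, a limit of the assay
- compound 3 `CSc1nc(N)nc2c1ncn2/C=C1/CC1(CO)CO`: > 300000 nM, a limit of the assay

Compound 1 stands at the upper limit of this assay; no number is known for it. The same holds for compound 2 and for compound 3, as the limit of > 300000 nM in this assay, at which 3 of the 3 values shown sit, shows. The step that the two limits leave unreadable from compound 1 to compound 2, the step that the two limits leave unreadable from compound 1 to compound 3 and the step that the two limits leave unreadable from compound 2 to compound 3 are therefore unreadable; none of the three exchanges on the aromatic carbon gave a value that the assay could resolve.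

Compound 4 `CCCCCCOc1nc(N)nc2c1ncn2/C=C1/CC1(CO)CO` differs from compound 1 in one place: pentyl in place of trifluoromethyl on a saturated chain carbon bound to an oxygen on an aromatic ring. Within the data shown here, no measured step covers an exchange of this kind, and the three steps that are measured all sit between limits, so they give no direction and no size for the change from compound 1 to compound 4.

Given that every measured compound in this series stands at the limit, compound 4 is expected to behave likewise, with an estimated value of 300000 nM (range 100000 nM to 300000 nM). The expected step from compound 1 is a number no higher from compound 1 to compound 4 (the limit leaves the size open), which is unreadable in the same way as the measured steps.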

Compound 4, half-maximal cytotoxic concentration: > 200000 nM
Compound 4: only a limit was reported; the forecaster's own chance of this, stated with the estimate: 75%; the middle value is on the limit's open side.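

In this assay compound 4 gives > 200000 nM, a limit of the assay and not a number. The steps joining compound 4 to compound 1, compound 2 and compound 3 therefore cannot be read, since all four values are limits. The compounds shown leave open where any half-maximal cytotoxic concentration lies, and whether these exchanges change it at all.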